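Hydroxy to methoxy on compound 2

The source may hold more compounds than are shown below. What is called first, only, known or untested is meant among the compounds shown, and "the series" means these compounds.

Measured in a physicochemical assay for lipophilicity, at pH 7.4; a lower number here means a more polar compound, a higher number a more lipophilic compound:
- compound 1 `CCS(=O)(=O)c1ccc(CN(CC(C)C)S(=O)(=O)c2ccc3c(c2)C(O)CC(C2CCOCC2)O3)nc1`: 1.42
- compound 2 `CCc1ccc(N(CC(C)C)S(=O)(=O)c2ccc3c(c2)C(O)CC(C2CCOCC2)O3)cc1`: 4.12
- compound 3 `CC(C)CN(c1cc2ccccc2s1)S(=O)(=O)c1ccc2c(c1)C(O)CC(C1CCOCC1)O2`: 3.92

Compound 2 shares the upper end of this range, and the step to its nearest neighbour reads a number 0.20 log units lower from compound 2 to compound 3 (within the scatter). The remaining compound lies far off, with a number 2.70 log units higher from compound 1 to compound 2 (beyond the scatter) and a number 2.50 log units higher from compound 1 to compound 3 (beyond the scatter).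

Compound 4 `CCc1ccc(N(CC(C)C)S(=O)(=O)c2ccc3c(c2)C(OC)CC(C2CCOCC2)O3)cc1` differs from compound 2 by methyl in place of hydrogen on an oxygen on a saturated carbon, or hydroxy to methoxy.

Going by the values given here, none of the measured steps touches this oxygen. All of them exchange the group on a sulfonamide nitrogen, so their sizes, large or within the scatter, give no direct guide here. The expectation rests on the structural change alone and points to a modest move to a higher number in this assay. The expected change is a number 0.38 log units higher from compound 2 to compound 4 (beyond the scatter). Compound 4 is estimated at 4.5, with an expected range of 4.1 to 4.9.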

Compound 4, distribution coefficient: 4.69
The estimate for compound 4 lay 0.19 log units below the measured number; low and high end bracket the measured number.
By their numbers in this assay, from the lowest: compound 1; then compounds 3 and 2 (each within the scatter of the next); then compound 4.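

The oxygen on the saturated carbon is the first place outside the sulfonamide nitrogen shown to move the number: in this assay hydroxy to methoxy gives a number 0.57 log units higher from compound 2 to compound 4 (beyond the scatter). A single added methyl, with no change to the group on the sulfonamide nitrogen, is therefore enough to produce a step beyond the scatter in this series. Nothing available explains the size of this step.

As far as these compounds go, it remains open whether the same change gives a similar step on other sulfonamide nitrogen groups, such as the (5-(ethylsulfonyl)pyridin-2-yl)methyl of compound 1, where this assay starts from a much lower number. Also open, from the compounds shown here alone, is how a longer chain on this oxygen, such as ethyl or propyl, or an amine in place of the hydroxy, would read in this assay.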